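A Bromide in Place of the Nitrile on the Chain

A few compounds are considered here, and "the series" means these few. Any claim that something is new, unique, unknown or untested is made for them only; others in the source may bear on it.

Compound 1, `CSC(=O)CCCCc1cnc(C(=O)CCCCCCc2ccccc2)o1`, gives 1.4 nM in an assay for inhibition of Fatty-acid amide hydrolase 1 (Rattus norvegicus), using a Dixon plot, with a stated time of 3 h; a lower number here means a stronger inhibitor, a higher number a weaker inhibitor.
Compound 2, `N#CCCCCCc1cnc(C(=O)CCCCCCc2ccccc2)o1`, gives 4 nM in this assay.

In this assay, among the compounds with values here, compound 2 stands at the highest of the two numbers, and the single measured step that reaches it, a 2.9-fold higher number from compound 1 to compound 2 (0.46 log units; beyond the scatter), is modest yet beyond the scatter. Compound 3, `O=C(CCCCCCc1ccccc1)c1ncc(CCCCCBr)o1`, differs from compound 2 by bromo in place of cyano on a saturated chain carbon, five bonds along the chain from an aromatic carbon. The step from compound 1 to compound 2 bears on this change only loosely: it shows that exchanging the group at the end of this chain shifts the inhibition constant by a modest amount, but it gives no indication of which way a bromide would move it. Within the data shown here, with one modest step as the only guide, a modest step in either direction, or none beyond the scatter, is expected. Compound 3 is therefore estimated at 6 nM, within a range from 1.5 nM to 25 nM. The expected step is a 1.5-fold higher number from compound 2 to compound 3 (0.18 log units; within the scatter).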

Compound 3, inhibition constant: 5.9 nM
Compound 3: the middle estimate sits 1.0-fold (0.01 log units) above what was measured; the range from low to high includes it.
By their numbers in this assay, from the lowest: compound 1; then compounds 2 and 3 (each within the scatter of the next).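

In this assay, bromo in place of cyano at the end of this chain gives a 1.5-fold higher number from compound 2 to compound 3 (0.17 log units; within the scatter), so compound 2 and compound 3 cannot be told apart, although the change removes the triple bond and the one hydrogen-bond acceptor of the cyano group. The step to bromomethyl in place of (methylsulfanyl)carbonyl, a 4.2-fold higher number from compound 1 to compound 3 (0.62 log units; beyond the scatter), is modest, and among these three compounds only compound 1 stands apart from the others beyond the scatter. Nothing available explains these differences in the inhibition constant.

The compounds shown leave open how a carboxylic acid or an amine at the end of this chain would compare. They also leave open whether a longer chain carrying the bromide would keep compound 3's standing.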